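The source may hold more compounds than are shown below. What is called first, only, known or untested is meant among the compounds shown, and "the series" means these compounds.

Compound 1, with the structure `CCCOc1c(Br)cc(/C=C2\CCC/C(=C\c3ccccc3[N+](=O)[O-])C2=O)cc1OC`, was tested in a functional assay on MCF7 cells (Homo sapiens) for cytotoxicity, read by MTT assay (on this read-out lower numbers stand for stronger inhibition and higher numbers for weaker inhibition), where compound 1 gives 4.14 ug/mL. Compound 2, with the structure `COc1cccc(/C=C2\CCC/C(=C\c3cccc([N+](=O)[O-])c3)C2=O)c1OC`, carries a 3-nitrophenyl group on one side of the same core; in this assay compound 2 gives 5.14 ug/mL. Of the two numbers recorded, compound 1 holds the low end, and compound 2 sits within the usual scatter of it, so the two cannot be told apart on this read-out.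

Compound 3, with the structure `CCCOc1c(Br)cc(/C=C2\CCC/C(=C\c3cccc([N+](=O)[O-])c3)C2=O)cc1OC`, has not yet been measured. It differs from compound 1 only in the arrangement of the nitro group: 3-nitrophenyl in place of 2-nitrophenyl on a double-bonded chain carbon bound to a double-bonded ring carbon. For the measured compounds named here, no pair of measured compounds shows a step of exactly this kind, so its size is unknown from direct data. Going by the values given here, the only hint comes from compound 2, which also carries a 3-nitrophenyl group and lands close to compound 1. The step from compound 1 to compound 3 in this assay is expected to be small, a 1.1-fold higher number from compound 1 to compound 3 (0.05 log units; within the scatter), in no clear direction beyond the scatter. Compound 3 is therefore estimated to give 4.6 ug/mL, within the range 2.4 ug/mL to 9 ug/mL.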

Compound 3, half-maximal inhibitory concentration: 0.85 ug/mL
Compound 3: the middle estimate sits 5.4-fold (0.73 log units) above what was measured; the whole stated range lies above it.
By their numbers in this assay, from the lowest: compound 3; then compounds 1 and 2 (each within the scatter of the next).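

Swapping 2-nitrophenyl for 3-nitrophenyl on a double-bonded chain carbon bound to a double-bonded ring carbon gives a 4.9-fold lower number from compound 1 to compound 3 (0.69 log units; beyond the scatter) in this assay while the rest of the molecule stays the same. The earlier compounds shown here could not show this, since no measured pair isolated a single change, and here the two groups have identical atoms and identical counts of rings, double bonds and hydrogen-bond acceptors, so the arrangement of the nitro group on the phenyl ring alone separates compound 1 from compound 3. Nothing measured here accounts for why the arrangement matters so much at this position.

On these data alone, this is a single pair on one core in one cell line, so it remains open whether the same swap would give a step of similar size with other groups on the core of compound 1. As far as these compounds go, it also remains open whether the nitro group itself is needed at this position, or whether an amine, a carboxylic acid or a methoxy group on the same phenyl ring would give a similar number.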